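Shortening the hydroxycarbamoyl chain to compound 4

A few compounds are considered here, and "the series" means these few. Any claim that something is new, unique, unknown or untested is made for them only; others in the source may bear on it.

Measured in a functional assay on A549 cells (Homo sapiens) for inhibition, read by MTT assay, with a stated time of 72 h (on this read-out lower numbers stand for stronger inhibition and higher numbers for weaker inhibition), each value a limit and not a number:
- Compound 1 `Nc1nc2cc(-c3nn(CCCC(=O)NO)c4ncnc(N)c34)ccc2o1`: > 100000 nM
- Compound 2 `Nc1nc2cc(-c3nn(CCC(=O)NO)c4ncnc(N)c34)ccc2o1`: > 150000 nM
- Compound 3 `Nc1nc2cc(-c3nn(CCCCCC(=O)NO)c4ncnc(N)c34)ccc2o1`: > 100000 nM

Compound 3 has no number, only the limit > 100000 nM. This is the limit of > 100000 nM in this assay, at which 2 of the 3 values shown sit, and the remaining value is the limit of > 150000 nM in this assay, at which 1 of the 3 values shown sits.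

Compound 4 `Nc1nc2cc(-c3nn(CC(=O)NO)c4ncnc(N)c34)ccc2o1` carries hydroxycarbamoyl in place of 4-(hydroxycarbamoyl)butyl on a saturated chain carbon bound to an aromatic nitrogen.

The measured steps that bear on this also alter the chain: a step that the two limits leave unreadable from compound 1 to compound 2, a step that the two limits leave unreadable from compound 1 to compound 3 and a step that the two limits leave unreadable from compound 2 to compound 3. None has a readable size or direction. The expected move, a step that the limit leaves unreadable from compound 3 to compound 4, is therefore taken as none beyond the scatter.

The estimate for compound 4 is 120000 nM, ranging from 70000 nM to 200000 nM.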

Compound 4, half-maximal inhibitory concentration: 27700 nM
For compound 4 the middle estimate is 4.3-fold (0.64 log units) above the measured one; measured number outside the range, below it.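

In this assay, within the data shown here, the chain of compound 4 gives the first readable change at this position, whereas the steps among the three longer chains cannot be read. Hydroxycarbamoyl on a saturated chain carbon bound to an aromatic nitrogen gives an at least 3.6-fold lower number from compound 3 to compound 4 (0.55 log units; beyond the scatter), together with an at least 5.4-fold lower number from compound 2 to compound 4 (0.73 log units; beyond the scatter) and an at least 3.6-fold lower number from compound 1 to compound 4 (0.55 log units; beyond the scatter). All three steps lie beyond the scatter, making compound 4 the most potent of the four on this read-out.

Going by these compounds, how a carboxylic acid in place of the hydroxycarbamoyl group would read remains open. So does any order among compound 1, compound 2 and compound 3.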